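A few compounds are considered here, and "the series" means these few. Any claim that something is new, unique, unknown or untested is made for them only; others in the source may bear on it.

The series shares one core, seen in compound 1 `CNc1nc(NCCCN(C)C)c2oc(-c3ccccc3)cc2n1`, compound 2 `CNc1nc(NCCCN(C)C)c2sc(-c3cccc(C#N)c3)cc2n1` and compound 3 `CNc1nc(NCCCN(C)C)c2sc(-c3ccc(C(F)(F)F)cc3)cc2n1`, which differ only in the aryl group attached to the fused ring system. In a physicochemical assay for solubility, at pH 2 (on this read-out higher numbers stand for higher solubility and lower numbers for lower solubility), compound 1 gives 214 ug/mL. In this assay, among the measured compounds shown here, compound 3 gives 240 ug/mL, a value that sits within the usual scatter of the one for compound 1. For compound 2 this assay reports only a limit, > 100 ug/mL, so no number is known for it. Of the three values shown, one sits at that limit (the limit of > 100 ug/mL in this assay, at which 1 of the 3 values shown sits), which places compound 2 in the same broad region as the other two without fixing its position.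

Compound 4 `CNc1nc(NCCCN(C)C)c2sc(-c3ccoc3)cc2n1` is not yet measured in this assay. It differs from compound 2 by one change: furan-3-yl in place of 3-cyanophenyl on an aromatic carbon. With no measured step of this kind among the compounds shown, and with compound 1 and compound 3 both giving numbers near the limit reported for compound 2, the step from compound 2 to compound 4 is expected to be small, a step that the limit leaves unreadable from compound 2 to compound 4, not clearly beyond the scatter in either direction. On that basis compound 4 is estimated to give 230 ug/mL in this assay, with a likely range from 100 ug/mL to 550 ug/mL.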

Compound 4, solubility: 221 ug/mL
Compound 4: middle estimate off by 1.0-fold (0.02 log units), on the high side, and the stated range covers the measured number.
By their numbers in this assay, from the lowest: compounds 1, 4 and 3 (each within the scatter of the next).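

In this assay compound 2 carries only a limit, > 100 ug/mL, and no number. Among the compounds shown here, no step from compound 2 to compound 4 can therefore be read. The compounds shown leave open whether furan-3-yl in place of 3-cyanophenyl on an aromatic carbon shifts the value in this assay at all, and in which direction.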